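Nitrone series on a shared triazole-bearing core: benzyl to tert-butyl

A few compounds are considered here, and "the series" means these few. Any claim that something is new, unique, unknown or untested is made for them only; others in the source may bear on it.

Compound 1 `[O-]/[N+](=C\c1cn(-c2ccc(F)cc2)nn1)c1ccccc1` gives 9800 nM in a functional assay on MDA-MB-231 cells (Homo sapiens) for inhibition, read by MTT assay, with a stated time of 24 h; on this read-out higher numbers stand for weaker inhibition and lower numbers for stronger inhibition. Compound 2 `[O-]/[N+](=C\c1cn(-c2ccc(F)cc2)nn1)Cc1ccccc1`, in this assay, gives only a limit, > 100000 nM, and no number. Compound 3 `[O-]/[N+](=C\c1cn(-c2ccc(C(F)(F)F)cc2)nn1)Cc1ccccc1`, in this assay, likewise gives only a limit, > 100000 nM. Compound 2 thus stands at the top of the shown range, and the limit of > 100000 nM in this assay, at which 2 of the 3 values shown sit, marks where most of the series sits.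

The measured steps: an at least 10-fold higher number from compound 1 to compound 2 (1.00 log units; beyond the scatter); a step that the two limits leave unreadable from compound 2 to compound 3.

Compound 4 `CC(C)(C)/[N+]([O-])=C/c1cn(-c2ccc(F)cc2)nn1` differs from compound 2 by tert-butyl in place of benzyl on a double-bonded nitrogen. Of the measured steps only the first bears on the substituent on the double-bonded nitrogen, and it shows that leaving phenyl for benzyl weakened inhibition past the limit. The second step is not readable and gives no guidance. Nothing measured shows what tert-butyl does at this position, so the expectation is that compound 4 stays near the limit, with the step of a number no higher from compound 2 to compound 4 (the limit leaves the size open) expected to be small or not readable. Compound 4 is therefore estimated at 100000 nM, with a range from 20000 nM to 500000 nM.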

Compound 4, half-maximal inhibitory concentration: 66400 nM
Compound 4: middle estimate off by 1.5-fold (0.18 log units), on the high side, within the range that was stated.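

Among the groups shown on the double-bonded nitrogen other than phenyl, tert-butyl in compound 4 is the one that gives a number rather than a limit in this assay. Tert-butyl in place of benzyl gives an at least 1.5-fold lower number from compound 2 to compound 4 (0.17 log units; that floor lies within the scatter), so the change cannot be separated from the usual scatter on its floor alone, although the true gap could be larger. Tert-butyl in place of phenyl gives a 6.8-fold higher number from compound 1 to compound 4 (0.83 log units; beyond the scatter), so with the fluoro-substituted core, phenyl keeps the lower number against both alkyl-linked groups, benzyl and tert-butyl.

On these data alone, the trifluoromethyl change cannot be read, and the size of the benzyl gap remains open, as both benzyl compounds are limits, not numbers: the limit of > 100000 nM in this assay, at which 2 of the 4 values shown sit. As far as these compounds go, how a cyclohexyl group, a longer chain or a methoxy-bearing phenyl on this nitrogen would compare with phenyl remains open.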